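The compounds below may be only part of what the source reports. "The series", "measured", "known", "first", "only" and "open" are said of these compounds alone.

Compound 1 `CNC(=O)N1CCCc2ccc(NC(=O)c3ccc(-c4ccccc4)cc3)cc21`: 19.7%
Compound 2 `CNC(=O)N1CCCc2ccc(NC(=O)c3cccc(-c4cn[nH]c4)c3)cc21`: 27.9%

In a functional assay on MV4-11 cells (Homo sapiens) for antiproliferative activity, with a stated time of 6 days, tested at 1.56 uM (on this read-out lower numbers stand for a weaker effect and higher numbers for a stronger effect at the one concentration tested), compound 1 gives 19.7%, the lower of the two numbers recorded, while compound 2 gives 27.9% in this assay; the gap between them lies within the usual scatter, so the two measured compounds cannot be told apart. Compound 3 `CNC(=O)N1CCCc2ccc(NC(=O)c3ccc(-c4cccnc4)cc3)cc21` has not yet been measured. It differs from compound 1 in one place: pyridin-3-yl in place of phenyl on an aromatic carbon. Within the data shown here, no pair of measured compounds shows this change, so the data give no measured step to lean on. Since both recorded numbers are low and close together, only a small step is expected in this assay for compound 3, with no direction that would clearly reach beyond the scatter. The value expected for compound 3 is 24%, in a range from 5% to 48%. The expected step is a number 4.3 percentage points higher from compound 1 to compound 3 (within the scatter).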

Compound 3, a percentage reported as inhibition, at one concentration (the size of the read-out at that concentration, not a potency): 62.5%
Compound 3: the middle estimate sits 38.5 percentage points below what was measured; the whole stated range lies below it.
By their numbers in this assay, from the lowest: compounds 1 and 2 (each within the scatter of the next); then compound 3.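

In this assay, the swap of phenyl for pyridin-3-yl on an aromatic carbon, para to a large group, produces a large change (a number 42.8 percentage points higher from compound 1 to compound 3 (beyond the scatter)). This shows that the read-out at this position is sensitive to a single ring nitrogen, even though the heavy-atom count and ring size stay the same. Compounds 1 and 2 differ in more than one place and could not reveal this, and nothing measured here gives a reason for the step.

The compounds shown leave open whether the place of the ring nitrogen matters, which pyridin-2-yl or pyridin-4-yl on the same carbon would test, and whether a ring bearing an amine or a carboxylic acid would behave like pyridin-3-yl. Going by these compounds, it also remains open whether the gain in compound 3 would persist with changes elsewhere on the shared core.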